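This account rests on a few compounds, and the source may have more. Where it says the series, first, only, none or still open, it means among the compounds named here.

In an ADME assay on H9c2 cells (Rattus norvegicus) for cytotoxicity (a lower number here means a stronger inhibitor, a higher number a weaker inhibitor), compound 1 `CCCC(=O)Nc1nc2ccc(Cl)cc2s1` reaches only a limit, > 50000 nM. Compound 2 `CC(C)C(=O)Nc1nc2ccc(Cl)cc2s1` also reaches only a limit, > 50000 nM. As far as these compounds go, compound 3 `O=C(Nc1nc2ccc(Cl)cc2s1)C1CCC1` stands at a limit as well, > 50000 nM, so its true position is unknown. Compound 4 `O=C(CC1CC1)Nc1nc2ccc(Cl)cc2s1` has the same atoms joined differently: cyclopropylmethyl in place of cyclobutyl on a carbonyl carbon. Within the data shown here, three measured steps bear on this change: a step that the two limits leave unreadable from compound 1 to compound 2, a step that the two limits leave unreadable from compound 1 to compound 3 and a step that the two limits leave unreadable from compound 2 to compound 3. None of them gives a size, so they offer no direction for this assay, and the expectation rests on all three compounds sitting at the same limit. The estimated change is a step that the limit leaves unreadable from compound 3 to compound 4, with no step beyond the scatter expected. For compound 4 the estimated value is 70000 nM, within a range of 35000 nM to 200000 nM.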

Compound 4, half-maximal inhibitory concentration: > 50000 nM
Compound 4 was reported as a limit; the forecaster's own chance of this, stated with the estimate: 85%; the middle value does not contradict the limit.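

In this assay compound 4 gives only a limit, > 50000 nM. Its steps to compound 1, compound 2 and compound 3 therefore cannot be read: the limit of > 50000 nM in this assay, at which 4 of the 4 values shown sit.

The compounds shown leave open where the true values of all four lie and whether they differ at all.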